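Cytotoxicity of sulfonyl piperidines: a sulfonyl substituent swap

The compounds below may be only part of what the source reports. "The series", "measured", "known", "first", "only" and "open" are said of these compounds alone.

Compound 1 `CCCC(=O)N(Cc1ccccc1)C1CCN(S(=O)(=O)c2c(C)cc(C)cc2C)CC1` gives > 5000 nM in an ADME assay on HCT-116 cells (Homo sapiens) for cytotoxicity, read by CellTiter-Glo, with a stated time of 72 h; on this read-out higher numbers stand for weaker inhibition and lower numbers for stronger inhibition; this is a limit of the assay, not a number.
Compound 2 `CC1CCN(C2CCN(S(=O)(=O)c3cccnc3)CC2)CC1` gives > 10000 nM in this assay; this too is a limit.
Compound 3 `Cc1cc(C)c(S(=O)(=O)N2CCC(N3CCCCCC3)CC2)c(C)c1` gives > 5000 nM in this assay, again a limit.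

All three measured compounds sit at limits, so none shows a measurable effect on these cells. Compound 2 sits at the limit of > 10000 nM in this assay, at which 1 of the 3 values shown sits, while the other two sit at the limit of > 5000 nM in this assay, at which 2 of the 3 values shown sit.

Compound 4 `COc1cccc(S(=O)(=O)N2CCC(N3CCC(C)CC3)CC2)c1` has not yet been measured. It differs from compound 2 in one place: 3-methoxyphenyl in place of pyridin-3-yl on a sulfonyl sulfur.

Among the measured compounds shown here, with every value shown being a limit, there is no measured step to lean on. The change from compound 2 to compound 4 is expected to give no step beyond the scatter, a step that the limit leaves unreadable from compound 2 to compound 4. Compound 4 is estimated at 15000 nM, within 5000 nM to 50000 nM, and most likely to be reported as a limit as well.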

Compound 4, half-maximal inhibitory concentration: > 5000 nM
Compound 4: a limit, no number; the forecaster's own chance of this, stated with the estimate: 85%; the middle value is on the limit's open side.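

Compound 2 gives > 10000 nM in this assay, a limit. Compound 4 gives > 5000 nM, also a limit. Among the compounds shown here, no step between compound 2 and compound 4 can be read. The compounds shown leave open how toxic any of them actually is to these cells.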